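Notes on chloro-to-hydrogen steps in a small series

The source may report more compounds than this note shows. Statements on the series, on what has been measured and on what is new or still open speak of the compounds shown alone.

Compound 3 `C=C(c1ccc(Cl)c(Cl)c1Cl)C1COC2(CCCCC2)OO1` gives 9020 nM in a functional assay on HepG2 cells (Homo sapiens) for inhibition, read by MTT assay, with a stated time of 72 h; on this read-out lower numbers stand for stronger inhibition and higher numbers for weaker inhibition. Compound 1 `C=C(c1ccc(Cl)c(Cl)c1)C1COC2(CCCCC2)OO1` gives 83500 nM in this assay, and the step of a 9.3-fold higher number from compound 3 to compound 1 (0.97 log units; beyond the scatter) corresponds to hydrogen in place of chloro on an aromatic carbon. Compound 2 `C=C(c1ccc(Cl)c(Cl)c1Cl)C1COC(C)(C)OO1` gives 27300 nM in this assay; the difference between the core of compound 2 and the core of compound 3 is not broken down here. Compound 4 `C=C(c1ccc(Cl)cc1Cl)C1COC(C)(C)OO1` is not yet measured. Among the compounds with values here, it differs from compound 2 by hydrogen in place of chloro on an aromatic carbon, the same kind of change as the one from compound 3 to compound 1 but not the same: there the site was ortho to a chloro group, ortho to a large group and meta to a chloro group, here it is ortho to two chloro groups and meta to a large group. A step in the same direction is expected, a 5.5-fold higher number from compound 2 to compound 4 (0.74 log units; beyond the scatter), because the step of a 9.3-fold higher number from compound 3 to compound 1 (0.97 log units; beyond the scatter) went that way. Compound 4 is expected near 150000 nM, between 40000 nM and 500000 nM.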

Compound 4, half-maximal inhibitory concentration: 90500 nM
Compound 4: middle estimate off by 1.7-fold (0.22 log units), on the high side, and the stated range covers the measured number.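

In this assay the new step is a 3.3-fold higher number from compound 2 to compound 4 (0.52 log units; beyond the scatter) and runs the same way as the earlier one, so hydrogen in place of chloro goes with a higher number on both cores shown. The two steps differ in the core and also in the site of the chloro group, and these four compounds do not separate the two, so neither can be held responsible for the gap. The size of the step does not carry over from one core to the other: the same change on two cores in this assay, a 9.3-fold higher number (0.97 log units; beyond the scatter) from compound 3 to compound 1 and a 3.3-fold higher number (0.52 log units; beyond the scatter) from compound 2 to compound 4, 2.8-fold (0.45 log units) apart, beyond the scatter of two such steps

Still open, going by these compounds, is how loss of chloro at one and the same site reads on both cores. Also open, on these data alone, is how a fluoro or methoxy group in place of chloro on the aromatic carbon would compare with hydrogen.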